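From vinyl to 2-(methylsulfanyl)ethyl on a shared core

The compounds below may be only part of what the source reports. "The series", "measured", "known", "first", "only" and "open" are said of these compounds alone.

Going by the values given here, only two compounds with this shared core have numbers so far. In a functional assay on P388 cells (Mus musculus) for cytotoxicity (a higher number here means a weaker inhibitor, a lower number a stronger inhibitor), compound 1 `COC(=O)C[C@@H]1NC(=O)[C@@H](C)NC(=O)[C@@H]2Cc3ccc(OC)c(c3)Oc3ccc(cc3)C[C@@H](C(=O)N2C)N(C)C(=O)[C@H](C)NC(=O)[C@H](Cc2ccc(OC)cc2)N(C)C1=O` gives 41.7 nM and compound 2 `C=C[C@@H]1NC(=O)[C@@H](C)NC(=O)[C@@H]2Cc3ccc(OC)c(c3)Oc3ccc(cc3)C[C@@H](C(=O)N2C)N(C)C(=O)[C@H](C)NC(=O)[C@H](Cc2ccc(OC)cc2)N(C)C1=O` gives 25.7 nM on the same scale. Among the compounds with values here, compound 2 therefore stands level with compound 1, the only other compound measured, as the two values lie within the scatter of each other.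

Compound 3 `COc1ccc(C[C@H]2C(=O)N[C@@H](C)C(=O)N(C)[C@H]3Cc4ccc(cc4)Oc4cc(ccc4OC)C[C@@H](C(=O)N[C@H](C)C(=O)N[C@@H](CCSC)C(=O)N2C)N(C)C3=O)cc1` keeps the core and changes one group, with 2-(methylsulfanyl)ethyl in place of vinyl on a saturated ring carbon. Within the data shown here, the one measured step that bears on this change involves the same ring carbon, where vinyl replaced (methoxycarbonyl)methyl. That swap gave a 1.6-fold lower number from compound 1 to compound 2 (0.21 log units; within the scatter) and so did not move the number beyond the scatter. A single step is thin evidence, but on this basis no step beyond the scatter, in either direction, is expected in this assay for the new group. The estimate amounts to an expected 1.3-fold higher number from compound 2 to compound 3 (0.11 log units; within the scatter) and no more. For compound 3 the expected value is 33 nM with an estimated range from 11 nM to 100 nM around it.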

Compound 3, half-maximal inhibitory concentration: 20.4 nM
For compound 3 the middle estimate is 1.6-fold (0.21 log units) above the measured one, and the stated range covers the measured number.
By their numbers in this assay, from the lowest: compounds 3, 2 and 1 (each within the scatter of the next, the first and the last beyond it).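

This saturated ring carbon accepts a group quite unlike the first two: 2-(methylsulfanyl)ethyl brings a sulfur atom and has 4 heavy atoms against the 2 of vinyl, and it loses the double bond, yet in this assay the swap gives a 1.3-fold lower number from compound 2 to compound 3 (0.10 log units; within the scatter). Read along the side chain, (methylsulfanyl)methyl in place of methoxycarbonyl gives a 2.0-fold lower number from compound 1 to compound 3 (0.31 log units; beyond the scatter), the only step among these compounds to pass the scatter, and only modestly, while compound 2 stays within the scatter of both neighbours. Nothing measured here accounts for either step.

The three groups shown carry no net charge and all give numbers in a narrow band, so it remains open whether a charged group at this ring carbon, such as an amine or a carboxylic acid, would shift the number further. From the compounds shown here alone, it is equally open whether the sulfur itself matters, which a comparison with 2-methoxyethyl or a plain propyl chain at the same carbon would begin to address.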